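Swapping a silyl ether for an acetate on the core

A few compounds are considered here, and "the series" means these few. Any claim that something is new, unique, unknown or untested is made for them only; others in the source may bear on it.

Measured compounds:
- compound 1, `C=C1CC[C@@H]2[C@](C)(CO[Si](C(C)C)(C(C)C)C(C)C)[C@H](O)CC[C@@]2(C)[C@@H]1C/C=C1/C(=O)OC[C@H]1O`, 3.01 uM
- compound 2, `C=C1CC[C@@H]2[C@](C)(CO[Si](c3ccccc3)(c3ccccc3)C(C)(C)C)[C@H](OC(C)=O)CC[C@@]2(C)[C@@H]1C/C=C1/C(=O)OC[C@H]1O`, 10.9 uM
- compound 3, `C=C1CC[C@@H]2[C@](C)(COC(c3ccccc3)(c3ccccc3)c3ccccc3)[C@H](OC(C)=O)CC[C@@]2(C)[C@@H]1C/C=C1/C(=O)OC[C@H]1OC(C)=O`, 8.37 uM

The three compounds share one core and were tested in a functional assay on Lu1 cells (Homo sapiens) for cytotoxicity, read by sulforhodamine B assay; on this read-out higher numbers stand for an effect only at larger amounts of compound and lower numbers for an effect already at smaller amounts. Compound 1 gives the lowest of the three numbers; compound 3 sits nearest to it, and compound 2 is furthest away, both gaps lying beyond the usual scatter. Compound 4, `C=C1CC[C@@H]2[C@](C)(COC(C)=O)[C@H](O)CC[C@@]2(C)[C@@H]1C/C=C1/C(=O)OC[C@H]1O`, has not yet been measured. It differs from compound 1 in one place: a group of 3 heavy atoms (2 carbon, 1 oxygen; no ring) in place of a group of 10 heavy atoms (9 carbon, 1 silicon; no ring), on an oxygen on a saturated carbon. An acetyl group thus takes the place of the silicon-containing group on an oxygen on a saturated carbon.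

For the measured compounds named here, no measured pair shows exactly this change, so the expected step in this assay is uncertain. Compounds 2 and 3 carry bulkier groups at that oxygen and give higher numbers than compound 1, but nothing measured tells how a smaller group behaves. Compound 4 is therefore expected to fall near compound 1, with a step of a 1.5-fold higher number from compound 1 to compound 4 (0.17 log units; within the scatter) from compound 1 to compound 4. The estimate for compound 4 is 4.5 uM, ranging from 1.5 uM to 15 uM.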

Compound 4, concentration for half-maximal effect: 14 uM
Compound 4: the middle estimate sits 3.1-fold (0.49 log units) below what was measured; low and high end bracket the measured number.
By their numbers in this assay, from the lowest: compound 1; then compounds 3, 2 and 4 (each within the scatter of the next).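

In this assay, replacing the silicon-containing group with acetyl on this oxygen on a saturated carbon gives a 4.7-fold higher number from compound 1 to compound 4 (0.67 log units; beyond the scatter), so this position does respond to the change and a group with fewer heavy atoms does not by itself give a lower number. For the compounds shown here, this is the first single-place change at this oxygen, and it gives the position a direct reading, though only for this one pair. Nothing available explains the size of this step.

The pair swaps the silicon atom and the group's size together, so it cannot show which of the two matters, and a silicon-free group of similar size, such as a benzyl ether, would help separate them. Also open, as far as these compounds go, is how a methyl ether, a free hydroxyl or a longer acyl chain such as hexanoyl would read at this oxygen.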